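The source may report more compounds than this note shows. Statements on the series, on what has been measured and on what is new or still open speak of the compounds shown alone.

Compound 2 `CC(=O)Nc1nc(-c2cccc(NS(=O)(=O)c3ccc(C#CC4CCCCC4)cc3)c2)cs1` gives 1.2% in a functional assay on A-375 cells (Homo sapiens) for antiproliferative activity, read by trypan blue exclusion, with a stated time of 48 h, tested at 10 uM (a higher number here means a weaker effect of the compound at the concentration tested, a lower number a stronger effect), the lowest of the three numbers seen. Compound 3 `C#Cc1cccc(S(=O)(=O)Nc2cccc(-c3csc(NC(C)=O)n3)c2)c1` gives 18.6% and compound 1 `CC(=O)Nc1nc(-c2cccc(NS(=O)(=O)c3cccc(Br)c3)c2)cs1` gives 36%. The gap from compound 2 to each of these two compounds lies outside the usual scatter. Going by the values given here, the only measured step, a number 17.4 percentage points lower from compound 1 to compound 3 (beyond the scatter), concerns ethynyl in place of bromo, a different change from the one that leads to compound 4 `CCCCCCCCc1ccc(S(=O)(=O)Nc2cccc(-c3csc(NC(C)=O)n3)c2)cc1`, which differs from compound 2 by octyl in place of 2-cyclohexylethynyl on an aromatic carbon. Among the compounds with values here, no measured step tests this change. Since compound 2 already sits near the floor of this assay, compound 4 is expected to show a step of a number 8.8 percentage points higher from compound 2 to compound 4 (within the scatter), a small rise that may stay within the scatter. Compound 4 is therefore estimated at 10%, within 0.5% to 35%.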

Compound 4, a percentage reported as activity, at one concentration (the size of the read-out at that concentration, not a potency): < 1%
Compound 4 ended at the assay's limit (the forecaster's own chance of this, stated with the estimate: 0%); middle value at least 9 percentage points away from the limit.
By their numbers in this assay, from the lowest: compound 2; then compound 3; then compound 1. At a limit, below all of these: compound 4.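

In this assay, compound 4 gives < 1%, which is a limit of the assay and not a number. The step, a number at least 0.2 percentage points lower from compound 2 to compound 4 (that floor lies within the scatter), shows that on this aromatic carbon, para to a large group, octyl with no ring and no triple bond keeps the read-out as low as 2-cyclohexylethynyl does, so neither the ring nor the triple bond is required. Any further difference between these two groups cannot be read at this end of the assay: the limit of < 1% in this assay, at which 1 of the 4 values shown sits.

On these data alone, it remains open whether a shorter chain such as butyl, or an octyl chain ending in an amine or a carboxylic acid, would keep the number this low at the same place. As far as these compounds go, how compound 2 and compound 4 compare at lower concentrations also remains open.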